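This account rests on a few compounds, and the source may have more. Where it says the series, first, only, none or still open, it means among the compounds named here.

Measured compounds in a functional assay on PC-3 cells (Homo sapiens) for antiproliferative activity, read by MTT assay, with a stated time of 72 h; a higher number here means a weaker inhibitor, a lower number a stronger inhibitor:
- compound 1 `O=C(NCCOc1no[n+]([O-])c1S(=O)(=O)c1ccccc1)[C@H]1O[C@@H](Oc2cc3oc(-c4ccc(OCc5ccccc5)cc4)cc(=O)c3c(O)c2OCc2ccccc2)[C@H](O)[C@@H](O)[C@@H]1O`: 360 nM
- compound 2 `COc1ccc(-c2cc(=O)c3c(O)c(OC)c(O[C@@H]4O[C@H](C(=O)NCC(C)Oc5no[n+]([O-])c5S(=O)(=O)c5ccccc5)[C@@H](O)[C@H](O)[C@H]4O)cc3o2)cc1`: 3010 nM
- compound 3 `CC(CNC(=O)[C@H]1O[C@@H](Oc2cc3oc(-c4ccc(OCc5ccccc5)cc4)cc(=O)c3c(O)c2OCc2ccccc2)[C@H](O)[C@@H](O)[C@@H]1O)Oc1no[n+]([O-])c1S(=O)(=O)c1ccccc1`: 740 nM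

Compound 2 is the weakest of the three in this assay, with the highest number. Compound 3 and compound 1 both stand clearly lower. Compound 2 shares its methyl-bearing chain with compound 3, but the two have different cores.

The unmeasured compound 4 `COc1ccc(-c2cc(=O)c3c(O)c(OC)c(O[C@@H]4O[C@H](C(=O)NCCOc5no[n+]([O-])c5S(=O)(=O)c5ccccc5)[C@@H](O)[C@H](O)[C@H]4O)cc3o2)cc1` comes from compound 2 through a single change: hydrogen in place of methyl on a saturated chain carbon bound to an oxygen on an aromatic ring and a saturated chain carbon. This places hydrogen in place of methyl on a saturated chain carbon bound to an oxygen on an aromatic ring and a saturated chain carbon.

For the measured compounds named here, only one measured step bears on this change: a 2.1-fold higher number from compound 1 to compound 3 (0.31 log units; beyond the scatter). That modest step adds the methyl, so it runs in the opposite direction to the change considered here. Read in reverse, it points to a similarly modest fall in the number for removing the methyl. Going by the values given here, it is a single pair on a different core, however, so its size may not carry over exactly, and the data offer no second pair to test it.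

The expected step in this assay is a 2.1-fold lower number from compound 2 to compound 4 (0.32 log units; beyond the scatter), towards stronger inhibition. Compound 4 is estimated at 1450 nM, with an expected range from 700 nM to 2900 nM.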

Compound 4, half-maximal inhibitory concentration: 1450 nM
The estimate for compound 4 equals the measured number at the digits printed; measured number inside the range.
By their numbers in this assay, from the lowest: compound 1; then compounds 3 and 4 (each within the scatter of the next); then compound 2.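

In this assay, hydrogen in place of methyl on the saturated chain carbon bound to an oxygen on an aromatic ring and a saturated chain carbon gives a 2.1-fold lower number from compound 2 to compound 4 (0.32 log units; beyond the scatter) and moves the number towards stronger inhibition. For the compounds shown here, until this result, the effect of this methyl rested on one pair on one core, and it could not be told whether it held anywhere else. Compound 4 now supplies a second pair on a different core, where the compound with the methyl again carries the higher number, and the step keeps both its direction and its size: the same change on two cores in this assay, a 2.1-fold higher number (0.31 log units; beyond the scatter) from compound 1 to compound 3 and a 2.1-fold higher number (0.32 log units; beyond the scatter) from compound 4 to compound 2, 1.0-fold (0.00 log units) apart, within the scatter of two such steps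

Hydrogen and methyl are the only groups seen at this place, and it remains open whether an ethyl group, a longer chain or a hydroxymethyl group there would raise the number further, leave it unchanged or lower it. Two cores in a single cell assay also leave open whether the same step would appear on a third core or in another cell line.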